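Halogens on the benzyl group: compound 3 to compound 4

The source may report more compounds than this note shows. Statements on the series, on what has been measured and on what is new or still open speak of the compounds shown alone.

Compound 1 `Cc1ccc(/C=C(/SCc2ccc(F)cc2)C(=O)c2ccc(Cl)cc2)s1`: > 100000 nM (a limit, not a number)
Compound 2 `O=C(/C(=C\c1ccc(O)cc1)SCc1ccc(Cl)cc1)c1ccc(Cl)cc1`: 10000 nM
Compound 3 `O=C(/C(=C\c1ccc(O)cc1)SCc1ccc(Cl)c(Cl)c1)c1ccc(Cl)cc1`: 1000 nM

In a functional assay on DU-145 cells (Homo sapiens) for inhibition, read by trypan blue exclusion, with a stated time of 96 h (on this read-out higher numbers stand for weaker inhibition of growth and lower numbers for stronger inhibition of growth), compound 3 gives 1000 nM, the lowest of the numbers in the series. The nearest number belongs to compound 2, at 10000 nM. The entry for compound 1 is a limit of the assay.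

Compound 4 `O=C(/C(=C\c1ccc(O)cc1)SCc1ccc(F)cc1)c1ccc(Cl)cc1` is the next to be read. The change from compound 3 is 4-fluorophenyl in place of 3,4-dichlorophenyl on a saturated chain carbon bound to a sulfur, or 3,4-dichlorobenzyl to 4-fluorobenzyl. For the measured compounds named here, the only measured step that bears on it is a 10-fold lower number from compound 2 to compound 3 (1.00 log units; beyond the scatter), where chloro replaces hydrogen on an aromatic carbon of this same group. Going by the values given here, compound 4 carries no chloro on this group, and no measured step covers fluoro here. A step of similar size in the reverse direction, towards weaker inhibition of growth in this assay, is therefore expected. The estimated step is an 8.0-fold higher number from compound 3 to compound 4 (0.90 log units; beyond the scatter). For compound 4 the expected value is 8000 nM, with an estimated range of 2000 nM to 40000 nM.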

Compound 4, concentration for 50% growth inhibition: 25000 nM
Compound 4: the middle estimate sits 3.1-fold (0.49 log units) below what was measured; the measured number falls inside the stated range.
By their numbers in this assay, from the lowest: compound 3; then compound 2; then compound 4. At a limit, above all of these: compound 1.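

On the benzyl group bound to sulfur, fluoro can now be read against chloro: a 25-fold higher number from compound 3 to compound 4 (1.40 log units; beyond the scatter) and a 2.5-fold higher number from compound 2 to compound 4 (0.40 log units; beyond the scatter), so in this assay the three compounds with the 4-hydroxyphenyl group run in the order 3,4-dichlorobenzyl, then the monochloro compound 2, then 4-fluorobenzyl. For the compounds shown here, with 4-fluorobenzyl held constant, the other end of the molecule can also be read for the first time, with 4-hydroxyphenyl in place of 5-methylthiophen-2-yl giving an at least 4.0-fold lower number from compound 1 to compound 4 (0.60 log units; beyond the scatter). Compound 1 stands at a limit, so that step gives only a bound: the limit of > 100000 nM in this assay, at which 1 of the 4 values shown sits.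

Going by these compounds, whether the order holds for bromo or methyl on the benzyl group remains open. So does what a methoxy group or an amine would do in place of the hydroxyl on the 4-hydroxyphenyl group.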